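This account rests on a few compounds, and the source may have more. Where it says the series, first, only, none or still open, it means among the compounds named here.

Measured so far in an ADME assay on HEK293 cells (Homo sapiens) for cytotoxicity, with a stated time of 72 h; a higher number here means that more compound is needed for the effect, a lower number that less compound is needed:
- Compound 1, `CCc1ccc(NC(=O)Nc2cc(C)nc3ccccc23)cc1`: 16000 nM
- Compound 3, `Cc1cc(NC(=O)Nc2cccc(C(F)(F)F)c2)c2ccccc2n1`: 16000 nM
- Compound 2, `Cc1cc(NC(=O)Nc2cc(F)cc(F)c2)c2ccccc2n1`: a limit of the assay, > 25000 nM

All three share one core, a urea joining that core to a second aromatic ring that carries a single substituent. On the numbers shown, compound 1 sits level with compound 3; the two values lie within the usual scatter of each other, so no order between them can be read. The value of compound 2 is a limit of the assay and not a number, as set out in the limit of > 25000 nM in this assay, at which 1 of the 3 values shown sits.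

Compound 4, `Cc1cc(NC(=O)Nc2ccc(Cl)cc2)c2ccccc2n1`, has not yet been measured. It differs from compound 1 in one place: chloro in place of ethyl on an aromatic carbon. Within the data shown here, no pair of measured compounds differs in just this way, so the size of the step can only be guessed from how little the substituted ring has mattered so far. In this assay the step is expected to stay within the scatter, with no clear direction. The expected value of compound 4 is 18000 nM, ranging from 8000 nM to 40000 nM, an expected step of a 1.1-fold higher number from compound 1 to compound 4 (0.05 log units; within the scatter).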

Compound 4, half-maximal effective concentration: > 25000 nM
Compound 4: a limit, no number; the forecaster's own chance of this, stated with the estimate: 35%; middle value at least 1.3-fold (0.14 log units) away from the limit.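

Chloro in place of ethyl on this aromatic carbon gives an at least 1.5-fold higher number from compound 1 to compound 4 (0.19 log units; that floor lies within the scatter) in this assay, the first change at this position that can be read on its own. Going by these compounds, the value of compound 4 is a limit of the assay and not a number, so this step is only a floor, and that floor does not clear the usual scatter; the true size of the change stays unknown. With compound 4, the assay limit now applies to more of the series: the limit of > 25000 nM in this assay, at which 2 of the 4 values shown sit.

The compounds shown leave open how an amine, a carboxylic acid or a longer chain at this position would read in this assay. They also leave open how far past the limit compound 2 and compound 4 actually lie.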